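Replacing a Methyl Group With Fluoro: Expected Stability

The source may report more compounds than this note shows. Statements on the series, on what has been measured and on what is new or still open speak of the compounds shown alone.

an ADME assay on microsomes from liver (Homo sapiens) for metabolic stability, using NADPH, with a stated time of 40 min, tested at 2 uM (on this read-out higher numbers stand for a longer-lived compound and lower numbers for a shorter-lived compound), is the read-out followed here. Compound 1 `Clc1cccc2c(-c3ccc4ccccc4n3)c[nH]c12` gives 0.283 h in this assay, compound 2 `Cc1cccc2c(-c3ccc4ccc(F)cc4n3)c[nH]c12` gives 0.883 h, and compound 3 `Cc1cc(Cl)c2[nH]cc(-c3ccc4ccccc4n3)c2c1` gives 0.3 h. Compound 3 thus stands second highest of the three numbers, with compound 1 nearest and compound 2 furthest, a gap that lies beyond the scatter. Among the measured compounds shown here, the single measured step that changes one place, a 1.1-fold higher number from compound 1 to compound 3 (0.03 log units; within the scatter), brings methyl in place of hydrogen on an aromatic carbon and stays within the scatter.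

Compound 4 `Fc1cc(Cl)c2[nH]cc(-c3ccc4ccccc4n3)c2c1` differs from compound 3 in one place: fluoro in place of methyl on an aromatic carbon. For the measured compounds named here, no measured pair shows fluoro replacing methyl, so only the flat step from compound 1 to compound 3 touches this region of the molecule. The step is therefore expected to be small and within the scatter, a 1.3-fold higher number from compound 3 to compound 4 (0.12 log units; within the scatter). Compound 4 is estimated at 0.4 h in this assay. The expected range runs from 0.2 h to 0.8 h.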

Compound 4, half-life: 0.383 h
Compound 4: the middle estimate sits 1.0-fold (0.02 log units) above what was measured; measured number inside the range.
By their numbers in this assay, from the lowest: compounds 1, 3 and 4 (each within the scatter of the next); then compound 2.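

On the ring that carries the chloro group, at the carbon meta to that chloro group, fluoro can now be set against both methyl and hydrogen. In this assay fluoro in place of methyl gives a 1.3-fold higher number from compound 3 to compound 4 (0.11 log units; within the scatter) and fluoro in place of hydrogen gives a 1.4-fold higher number from compound 1 to compound 4 (0.13 log units; within the scatter) in a second comparison. Neither step can be read as a real difference, so hydrogen, methyl and fluoro at this carbon cannot be told apart on this read-out. Nothing measured here gives a reason for this flat result.

On these data alone, whether the position stays as flat with an amine, a carboxylic acid or a longer chain remains open. Also open, as far as these compounds go, is whether fluoro at this carbon would read the same on a core without the chloro group.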